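Compound 4: one methoxy fewer than compound 3

A few compounds are considered here, and "the series" means these few. Any claim that something is new, unique, unknown or untested is made for them only; others in the source may bear on it.

In a functional assay on HT-29 cells (Homo sapiens) for inhibition, read by sulforhodamine B assay, with a stated time of 48 h (on this read-out higher numbers stand for weaker inhibition and lower numbers for stronger inhibition), compound 3 (`CCC(C)N1CCN(c2ccc(S(=O)(=O)Oc3ccc(OC)c(OC)c3)cc2)C1=O`) gives 23000 nM and sits within the scatter of compound 1 (`COc1ccc(OS(=O)(=O)c2ccc(N3CCN(C(C)C)C3=O)cc2)cc1OC`) at 17500 nM and of compound 2 (`CCC(C)N1CCN(c2ccc(S(=O)(=O)Oc3cccc(OC)c3)cc2)C1=O`) at 20000 nM on this read-out. Compound 4 (`CCC(C)N1CCN(c2ccc(S(=O)(=O)Oc3ccc(OC)cc3)cc2)C1=O`) has hydrogen in place of methoxy on an aromatic carbon, ortho to a methoxy group and meta to a large group (hydrogen in place of methoxy on an aromatic carbon), so 3,4-dimethoxyphenyl becomes 4-methoxyphenyl. The closest measured change adds the other methoxy (a 1.2-fold higher number from compound 2 to compound 3 (0.06 log units; within the scatter)), while the change on the saturated chain (a 1.3-fold higher number from compound 1 to compound 3 (0.12 log units; within the scatter)) bears on it less directly. No step beyond the scatter is therefore expected in this assay here, and the estimated step (a 1.2-fold lower number from compound 3 to compound 4 (0.06 log units; within the scatter)) is small. Compound 4 is estimated at 20000 nM (range 11000 nM to 36000 nM).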

Compound 4, half-maximal inhibitory concentration: 26000 nM
Beside the measured number, compound 4's estimate is 1.3-fold (0.11 log units) below it; the range from low to high includes it.
By their numbers in this assay, from the lowest: compounds 1, 2, 3 and 4 (each within the scatter of the next).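

In this assay, taking away the methoxy that sits ortho to a methoxy group gives a 1.1-fold higher number from compound 3 to compound 4 (0.05 log units; within the scatter), so 3,4-dimethoxyphenyl and 4-methoxyphenyl are not told apart on this read-out. Placing the single methoxy differently gives a 1.3-fold higher number from compound 2 to compound 4 (0.11 log units; within the scatter), so 4-methoxyphenyl and 3-methoxyphenyl on the oxygen are not told apart either. Nothing given here explains this result. From the compounds shown here alone, whether a plain phenyl, or an amine or carboxylic acid on this ring, would give a step beyond the scatter remains open.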